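Methylpyridinyl Amide in Place of a Halogenated Phenyl

A few compounds are considered here, and "the series" means these few. Any claim that something is new, unique, unknown or untested is made for them only; others in the source may bear on it.

In an assay on isolated protein for inhibition of histone deacetylase 8 (Homo sapiens), with a stated time of 1 h (on this read-out higher numbers stand for weaker inhibition and lower numbers for stronger inhibition), compound 1 `Cc1ccc(NC(=O)COc2ccc3cc(/C=C4/SC(=O)NC4=O)ccc3c2)cc1` gives 9000 nM.
Compound 2 `O=C(COc1ccc2cc(/C=C3/SC(=O)NC3=O)ccc2c1)Nc1c(F)cc(F)cc1Br` in this assay reaches only > 50000 nM, a limit rather than a number.

Compound 2 therefore stands at the weaker end of the two values shown, at the limit of > 50000 nM in this assay, at which 1 of the 2 values shown sits. Compound 3 `Cc1cccc(NC(=O)COc2ccc3cc(/C=C4/SC(=O)NC4=O)ccc3c2)n1` differs from it by 6-methylpyridin-2-yl in place of 2-bromo-4,6-difluorophenyl on an amide-type nitrogen. Among the compounds with values here, the one measured step that bears on this change is an at least 5.5-fold higher number from compound 1 to compound 2 (0.74 log units; beyond the scatter), which introduced the very group that now leaves. Reversing that group, compound 3 is expected to move back toward a lower number, a step of an at least 3.3-fold lower number from compound 2 to compound 3 (0.52 log units; beyond the scatter). The estimate for compound 3 is 15000 nM, ranging from 5000 nM to 50000 nM.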

Compound 3, half-maximal inhibitory concentration: 7500 nM
The estimate for compound 3 lay 2.0-fold (0.30 log units) above the measured number; measured number inside the range.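

Putting 6-methylpyridin-2-yl in place of 2-bromo-4,6-difluorophenyl on the amide-type nitrogen gives an at least 6.6-fold lower number from compound 2 to compound 3 (0.82 log units; beyond the scatter), so the loss of inhibition seen with the halogenated phenyl does not carry over to this group. Compared with compound 1, the same position gives a 1.2-fold lower number from compound 1 to compound 3 (0.08 log units; within the scatter), so 6-methylpyridin-2-yl and 4-methylphenyl cannot be told apart here. Compound 2 remains a limit and not a number: the limit of > 50000 nM in this assay, at which 1 of the 3 values shown sits.

The compounds shown leave open whether the bromine or the fluorine atoms account for that loss. They also leave open how an amine or a carboxylic acid on this ring would fare.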